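The source may hold more compounds than are shown below. What is called first, only, known or untested is meant among the compounds shown, and "the series" means these compounds.

Among the measured compounds shown here, in an ADME assay on HFL1 cells (Homo sapiens) for inhibition, read by thymidine incorporation, with a stated time of 48 h (a higher number here means a weaker inhibitor, a lower number a stronger inhibitor), compound 1 (`Cc1cc(-c2ccnc3[nH]nc(C(F)(F)F)c23)cc(C2(CN)CCC2)c1`) gives 650 nM, the lower of the two numbers so far, which makes it the stronger inhibitor of the pair. Compound 2 (`NCC1(c2cccc(-c3ccnc4[nH]nc(C(F)(F)F)c34)c2)CCC1`) has hydrogen in place of methyl on an aromatic carbon and gives 1900 nM. For the measured compounds named here, that is the only measured step, a 2.9-fold higher number from compound 1 to compound 2 (0.47 log units; beyond the scatter), and it counts as modest.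

Compound 3 (`Cc1cc(-c2ccnc3[nH]nc(C(F)(F)F)c23)cc(C2(CN)COC2)c1`) keeps the methyl group of compound 1 and changes a different group: 3-(aminomethyl)oxetan-3-yl in place of 1-(aminomethyl)cyclobutyl on an aromatic carbon. In words, 3-(aminomethyl)oxetan-3-yl stands in place of 1-(aminomethyl)cyclobutyl on an aromatic carbon.

Going by the values given here, no measured compound carries this new four-membered ring, so the data offer no direct guide to the swap. Among the compounds with values here, the one measured step bears on it only indirectly, showing that a single change of group on this aromatic ring can shift the number by a modest amount. A step of similar size is a reasonable guess, and the direction is a judgment rather than a finding. The expected step is a 1.8-fold higher number from compound 1 to compound 3 (0.27 log units; within the scatter), towards a somewhat weaker inhibitor. For compound 3, the estimated value is 1200 nM, with an expected range of 400 nM to 3600 nM.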

Compound 3, half-maximal inhibitory concentration in the HFL1 assay: 2500 nM
Compound 3: middle estimate off by 2.1-fold (0.32 log units), on the low side, and the stated range covers the measured number.
By their numbers in the HFL1 assay, from the lowest: compound 1; then compounds 2 and 3 (each within the scatter of the next).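

The group carrying the aminomethyl chain turns out to matter in its own right: in the HFL1 assay, replacing 1-(aminomethyl)cyclobutyl with 3-(aminomethyl)oxetan-3-yl gives a 3.8-fold higher number from compound 1 to compound 3 (0.59 log units; beyond the scatter), a move towards a weaker inhibitor. Among the compounds shown here, the earlier step concerned only the methyl group, so this is the first sign that the four-membered ring at this place on the aromatic ring affects the number, even though both rings have the same number of heavy atoms and the change keeps the aminomethyl chain in place. The same swap also shifts a second property, as a physicochemical assay for lipophilicity (on this read-out lower numbers stand for lower lipophilicity and higher numbers for higher lipophilicity), shows, so the change in inhibition comes with a measured change in lipophilicity: the measured distribution coefficient of compound 1, 2.9, and of compound 3, 2.2, a number 0.70 log units lower (beyond the scatter) In the physicochemical assay compound 1 gives 2.9 and compound 3 gives 2.2.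

Since both shifts come from this single pair, the data cannot say whether one drives the other or whether the ring oxygen acts in some separate way. Also open, from the compounds shown here alone, is how a five-membered tetrahydrofuran ring or a cyclobutane ring bearing two fluorines would behave at this place, and whether the oxetane swap gives a step of similar size without the methyl group.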